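The source may report more compounds than this note shows. Statements on the series, on what has been measured and on what is new or still open speak of the compounds shown alone.

Three compounds share one core and differ only in the group on the aromatic carbon. Compound 1 `Cc1cc(C(=O)Nc2ccc(F)cc2)nn1Cc1cc(Cl)ccc1OCc1ccccc1` gives 79.4 nM in an assay on CHO-K1 cells for displacement of a labelled ligand from prostaglandin E2 receptor EP1 subtype (Homo sapiens); a lower number here means a stronger inhibitor, a higher number a weaker inhibitor. Compound 2 `Cc1cc(C(=O)NCc2cccnc2)nn1Cc1cc(Cl)ccc1OCc1ccccc1` gives 50.1 nM in this assay; the step of a 1.6-fold lower number from compound 1 to compound 2 (0.20 log units; within the scatter) stays within the scatter. Compound 3 `Cc1cc(NC(=O)CC2CCCCC2)nn1Cc1cc(Cl)ccc1OCc1ccccc1` gives 6.31 nM in this assay, the lowest number of the three, with a 13-fold lower number from compound 1 to compound 3 (1.10 log units; beyond the scatter) and a 7.9-fold lower number from compound 2 to compound 3 (0.90 log units; beyond the scatter) both beyond the scatter.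

Compound 4 `Cc1cc(NC(=O)C2CCCO2)nn1Cc1cc(Cl)ccc1OCc1ccccc1` keeps the amino-linked carbonyl of compound 3 and changes only what sits on that carbonyl carbon: oxolan-2-yl in place of cyclohexylmethyl on a carbonyl carbon. Among the measured compounds shown here, none of the measured steps tests this swap; the two large steps that reach compound 3 each change the direction of the amide link together with the group on it, so they only show that the (cyclohexylmethyl)carbonyl)amino arrangement is the best measured. The data give no guide to an oxolan-2-yl on that carbonyl. Compound 4 is therefore expected to come out weaker than compound 3, by a step of a 6.3-fold higher number from compound 3 to compound 4 (0.80 log units; beyond the scatter) in this assay, with wide uncertainty. The estimate for compound 4 in this assay is 40 nM, within a range from 10 nM to 200 nM.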

Compound 4, half-maximal inhibitory concentration in the prostaglandin E2 receptor EP1 subtype assay: 39.8 nM
Compound 4: middle estimate off by 1.0-fold (0.00 log units), on the high side; low and high end bracket the measured number.
By their numbers in the prostaglandin E2 receptor EP1 subtype assay, from the lowest: compound 3; then compounds 4, 2 and 1 (each within the scatter of the next).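

In the prostaglandin E2 receptor EP1 subtype assay, with the amino-linked carbonyl held fixed, compound 4 gives 39.8 nM, and the change from cyclohexylmethyl to oxolan-2-yl gives a 6.3-fold higher number from compound 3 to compound 4 (0.80 log units; beyond the scatter), the first measured sign that the group on this carbonyl carbon matters apart from the direction of the amide link. The amino-linked carbonyl alone therefore does not secure the number of compound 3, since the steps of a 1.3-fold lower number from compound 2 to compound 4 (0.10 log units; within the scatter) and a 2.0-fold lower number from compound 1 to compound 4 (0.30 log units; within the scatter) leave compound 4 level with the two carbamoyl compounds. In a physicochemical assay for lipophilicity, at pH 7.4 (on this read-out higher numbers stand for higher lipophilicity and lower numbers for lower lipophilicity), compound 3 gives 3.2. In the physicochemical assay compound 4 stands at > 3.7, a limit of the assay and not a number: the limit of > 3.7 in the physicochemical assay, at which 1 of the 2 values shown sits.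

The change swaps ring size, ring atoms and the methylene link at once, so the compounds shown do not separate these. From the compounds shown here alone, it remains open how cyclopentyl, cyclohexyl or an open-chain methoxymethyl on the same carbonyl carbon would read in the prostaglandin E2 receptor EP1 subtype assay.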